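The source may report more compounds than this note shows. Statements on the series, on what has been measured and on what is new or still open speak of the compounds shown alone.

Compound 3 `N#Cc1ccc(Cn2cc(COc3ccc([N+](=O)[O-])cc3)nn2)cc1` is one of three compounds that share a common core and differ only in the group on one aromatic carbon. In an assay on isolated protein for inhibition of Aromatase (Homo sapiens), read by fluorescence and colorimetric assay, with a stated time of 30 min (on this read-out higher numbers stand for weaker inhibition and lower numbers for stronger inhibition), compound 3 gives 5620 nM. Compound 1 `N#Cc1ccc(Cn2cc(COc3ccccc3)nn2)cc1`, which carries hydrogen at that position, gives 6090 nM, and compound 2 `N#Cc1ccc(Cn2cc(COc3ccc(C#N)cc3)nn2)cc1`, which carries cyano there, gives 9160 nM. The changes among them are small: a 1.1-fold lower number from compound 1 to compound 3 (0.03 log units; within the scatter), a 1.6-fold lower number from compound 2 to compound 3 (0.21 log units; within the scatter), and a 1.5-fold higher number from compound 1 to compound 2 (0.18 log units; within the scatter), so compound 3 stands within the scatter of both neighbours.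

Compound 4 `Cc1ccc(OCc2cn(Cc3ccc(C#N)cc3)nn2)cc1` arises from compound 3 by methyl in place of nitro on an aromatic carbon. All three measured steps bear directly on this change, since each swaps the group on the same aromatic carbon, and none of them moved the number beyond the scatter. A further swap at this position is therefore expected to bring little change, so that a 1.1-fold higher number from compound 3 to compound 4 (0.03 log units; within the scatter) is the step estimated. For compound 4 the estimated value in this assay is 6000 nM, with a range from 3000 nM to 12000 nM.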

Compound 4, half-maximal inhibitory concentration: 4170 nM
Beside the measured number, compound 4's estimate is 1.4-fold (0.16 log units) above it; the measured number falls inside the stated range.
By their numbers in this assay, from the lowest: compounds 4, 3, 1 and 2 (each within the scatter of the next, the first and the last beyond it).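

Methyl, on an aromatic carbon para to a large group, gives the first step at this position that lies beyond the scatter in this assay with a 2.2-fold lower number from compound 2 to compound 4 (0.34 log units; beyond the scatter) as a modest change. The other two steps, a 1.3-fold lower number from compound 3 to compound 4 (0.13 log units; within the scatter) and a 1.5-fold lower number from compound 1 to compound 4 (0.16 log units; within the scatter), remain within the scatter, so hydrogen, nitro and methyl cannot be told apart here, and only methyl and cyano are separated by a measurable gap.

On these data alone, what an amine, a carboxylic acid or a longer chain would do on this carbon remains open. So does the question of whether any group here can shift the number by more than this modest step. Nothing given here explains why methyl and cyano differ.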